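From dimethoxyphenyl to trifluorophenyl at the assay limit

This account rests on a few compounds, and the source may have more. Where it says the series, first, only, none or still open, it means among the compounds named here.

Of the compounds shown here, three sharing one core have been measured: compound 1 (`OC[C@H]1O[C@@H](n2cnc3c(NCc4cccc(Br)c4)ncnc32)[C@H](O)[C@@H]1O`), compound 2 (`COc1cccc(CNc2ncnc3c2ncn3[C@@H]2O[C@H](CO)[C@@H](O)[C@H]2O)c1OC`) and compound 3 (`COc1ccc(CNc2ncnc3c2ncn3[C@@H]2O[C@H](CO)[C@@H](O)[C@H]2O)c(OC)c1`). In a functional assay on HOS cells (Homo sapiens) for antiproliferative activity, with a stated time of 72 h (a higher number here means a weaker inhibitor, a lower number a stronger inhibitor), compound 1 gives > 166000 nM as a limit and not a number. In this assay compound 2 gives > 166000 nM as a limit as well. In this assay compound 3 gives > 166000 nM as a limit too, so it has no number of its own. All readings so far come to one result (the limit of > 166000 nM in this assay, at which 3 of the 3 values shown sit).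

Compound 4 (`OC[C@H]1O[C@@H](n2cnc3c(NCc4ccc(F)c(F)c4F)ncnc32)[C@H](O)[C@@H]1O`) differs from compound 3 by one change (2,3,4-trifluorophenyl in place of 2,4-dimethoxyphenyl on a saturated chain carbon bound to a nitrogen on an aromatic ring): 2,3,4-trifluorophenyl in place of 2,4-dimethoxyphenyl on a saturated chain carbon bound to a nitrogen on an aromatic ring.

The measured swaps at this place bear on it (a step that the two limits leave unreadable from compound 1 to compound 2), (a step that the two limits leave unreadable from compound 1 to compound 3) and (a step that the two limits leave unreadable from compound 2 to compound 3), but none of them has a readable size. With compound 3 held at > 166000 nM as a limit, no step beyond the scatter is expected in this assay and any movement would be towards stronger inhibition. The estimated step is an at least 1.1-fold lower number from compound 3 to compound 4 (0.04 log units; that floor lies within the scatter) and no more than that is expected. The estimated value for compound 4 is 150000 nM within an expected range from 30000 nM to 166000 nM and a report as a limit only is likely.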

Compound 4, half-maximal inhibitory concentration: > 166000 nM
Compound 4: only a limit was reported (the forecaster's own chance of this, stated with the estimate: 70%); middle value at least 1.1-fold (0.04 log units) away from the limit.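

In this assay compound 4 gives > 166000 nM as a limit and not a number. Its steps from compound 1, compound 2 and compound 3 therefore cannot be read, and the series stays at one result: the limit of > 166000 nM in this assay, at which 4 of the 4 values shown sit.

The compounds shown leave open whether any group at this place on the shared core gives a measurable value.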